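From 2,4-dichlorobenzyl to 3,4-dichlorobenzyl on a shared core

The source may report more compounds than this note shows. Statements on the series, on what has been measured and on what is new or still open speak of the compounds shown alone.

In a functional assay on K562 cells (Homo sapiens) for antiproliferative activity, with a stated time of 72 h (on this read-out higher numbers stand for weaker inhibition and lower numbers for stronger inhibition), three compounds sharing one core have been measured. Compound 1 `OC[C@H]1O[C@@H](n2cnc3c(NCc4ccccc4F)ncnc32)[C@H](O)[C@@H]1O` gives 33200 nM, compound 2 `OC[C@H]1O[C@@H](n2cnc3c(NCc4ccccc4Br)ncnc32)[C@H](O)[C@@H]1O` gives 10000 nM, and compound 3 `OC[C@H]1O[C@@H](n2cnc3c(NCc4ccc(Cl)cc4Cl)ncnc32)[C@H](O)[C@@H]1O` gives 106000 nM. Compound 3 therefore has the highest number of the three and is the weakest inhibitor so far. Compound 4 `OC[C@H]1O[C@@H](n2cnc3c(NCc4ccc(Cl)c(Cl)c4)ncnc32)[C@H](O)[C@@H]1O` has not yet been measured. It differs from compound 3 as follows: 3,4-dichlorophenyl in place of 2,4-dichlorophenyl on a saturated chain carbon bound to a nitrogen on an aromatic ring. This places 3,4-dichlorophenyl in place of 2,4-dichlorophenyl on a saturated chain carbon bound to a nitrogen on an aromatic ring.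

Within the data shown here, no measured step makes this exact change, so the evidence is indirect. The closest steps are the large 11-fold higher number from compound 2 to compound 3 (1.03 log units; beyond the scatter) and the modest 3.2-fold higher number from compound 1 to compound 3 (0.50 log units; beyond the scatter), both of which end at 2,4-dichlorophenyl. The modest 3.3-fold lower number from compound 1 to compound 2 (0.52 log units; beyond the scatter) shows a smaller shift among the other two compounds. With compound 3 at the top of the measured range, a modest move to a lower number is expected, estimated as a 2.4-fold lower number from compound 3 to compound 4 (0.37 log units; beyond the scatter). Compound 4 is expected at about 45000 nM, with an estimated range of 13000 nM to 150000 nM.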

Compound 4, half-maximal inhibitory concentration: 10800 nM
Estimate against measurement, compound 4: 4.2-fold (0.62 log units) above; the measured number lies below the stated range.
By their numbers in this assay, from the lowest: compounds 2 and 4 (each within the scatter of the next); then compound 1; then compound 3.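

In this assay, the 2,4-dichlorobenzyl and 3,4-dichlorobenzyl groups hold the same atoms joined differently, yet this change alone gives a 9.8-fold lower number from compound 3 to compound 4 (0.99 log units; beyond the scatter) in the read-out. At this position, then, the number depends on where the two chlorines stand on the ring and not only on their presence; the data also show a 3.1-fold lower number from compound 1 to compound 4 (0.49 log units; beyond the scatter) beyond the scatter, while a 1.1-fold higher number from compound 2 to compound 4 (0.03 log units; within the scatter) within it puts the 3,4-dichlorophenyl and 2-bromophenyl compounds level. Nothing measured here accounts for the size of the step from the 2,4-dichlorobenzyl to the 3,4-dichlorobenzyl compound.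

The compounds shown leave open how a methoxy group or an amine on the ring would compare with these halogens. They also leave open whether a longer chain between the ring and the nitrogen would keep the difference between the two dichlorophenyl arrangements.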